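Pyrrole for Pyridine on the Chalcone Carbonyl

The source may report more compounds than this note shows. Statements on the series, on what has been measured and on what is new or still open speak of the compounds shown alone.

The three measured compounds share one core and differ only in the ring on the carbonyl carbon. Compound 1 `COc1ccc(-c2cc3ccccc3nc2/C=C/C(=O)c2ccc(O)cc2)cc1` gives 6930 nM in a functional assay on NCI-H460 cells (Homo sapiens) for antiproliferative activity, read by XTT assay, with a stated time of 72 h; a lower number here means a stronger inhibitor, a higher number a weaker inhibitor. Compound 2 `COc1ccc(-c2cc3ccccc3nc2/C=C/C(=O)c2c(OC)cccc2OC)cc1` gives 6630 nM, and compound 3 `COc1ccc(-c2cc3ccccc3nc2/C=C/C(=O)c2ccccn2)cc1` gives 6260 nM. Compound 3 has the lowest of the three numbers, but its steps to the others are small: a 1.1-fold lower number from compound 1 to compound 3 (0.04 log units; within the scatter) and a 1.1-fold lower number from compound 2 to compound 3 (0.02 log units; within the scatter), both within the scatter, as is a 1.0-fold lower number from compound 1 to compound 2 (0.02 log units; within the scatter). On these numbers compound 3 is not separated from compound 1 or compound 2.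

Compound 4 `COc1ccc(-c2cc3ccccc3nc2/C=C/C(=O)c2ccc[nH]2)cc1` is not yet measured. It differs from compound 3 in one place: 1H-pyrrol-2-yl in place of pyridin-2-yl on a carbonyl carbon. For the measured compounds named here, no measured step swaps a six-membered ring for a five-membered one, so none bears on it directly. What the three steps do show is that a hydroxyphenyl, a dimethoxyphenyl and a pyridyl ring on that carbonyl carbon all gave numbers within the scatter of each other, so the ring at this position has so far moved the read-out little. The account therefore expects no step beyond the scatter for compound 4, in either direction, and sets a 1.0-fold lower number from compound 3 to compound 4 (0.02 log units; within the scatter) close to flat. From the compounds shown here alone, the estimate for compound 4 is 6000 nM, within a range from 2000 nM to 18000 nM, with the width reflecting that the pyrrole change is untested.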

Compound 4, half-maximal inhibitory concentration: > 10000 nM
Compound 4 gave a limit, no number; the forecaster's own chance of this, stated with the estimate: 5%; at least 1.6-fold (0.22 log units) between middle value and limit.
By their numbers in this assay, from the lowest: compounds 3, 2 and 1 (each within the scatter of the next). At a limit, above all of these: compound 4.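

Compound 4 carries a limit, not a number: the limit of > 10000 nM in this assay, at which 1 of the 4 values shown sits. Set against the three earlier compounds, 1H-pyrrol-2-yl on this carbonyl carbon gives an at least 1.5-fold higher number from compound 3 to compound 4 (0.20 log units; that floor lies within the scatter), an at least 1.5-fold higher number from compound 2 to compound 4 (0.17 log units; that floor lies within the scatter) and an at least 1.4-fold higher number from compound 1 to compound 4 (0.15 log units; that floor lies within the scatter), so each step is known only as a floor, and each floor lies within the scatter. This is the first five-membered ring shown at this position, and although its result does not establish a step beyond the scatter, it is also the first to lie past the assay's limit, so the flat picture from the three six-membered rings cannot simply be extended to it.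

The compounds shown leave open how far the true value of compound 4 lies from those of compounds 1, 2 and 3, and whether any difference goes with the ring size or with the hydrogen on the pyrrole nitrogen. A furan ring, a thiophene ring or a methyl group on the pyrrole nitrogen, each on this same carbonyl carbon, would bear on that question.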